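The source may report more compounds than this note shows. Statements on the series, on what has been measured and on what is new or still open speak of the compounds shown alone.

Measured compounds:
- compound 1, `Cc1ccc(S(=O)(=O)N2C=CNC(=O)[C@H]2CC(=O)N[C@@H]2CCCc3ccccc32)cc1` — 3.3 nM
- compound 2, `Cc1ccc(S(=O)(=O)N2C=CNC(=O)[C@H]2CC(=O)NC2CCNc3ccccc32)cc1` — 21.6 nM

In an in vitro functional assay on cells for antagonist activity at B1 bradykinin receptor (Homo sapiens), read by luminescence and calcium flux, with a stated time of 2 h (a lower number here means a stronger inhibitor, a higher number a weaker inhibitor), compound 1 gives the lower of the two numbers; compound 2 sits at a 6.5-fold higher number from compound 1 to compound 2 (0.82 log units; beyond the scatter), a change in the ring-bearing part of the amide substituent. Compound 3, `Cc1ccc(S(=O)(=O)N2C=CNC(=O)[C@H]2CC(=O)N[C@@H]2CCC(O)c3ccccc32)cc1`, instead carries hydroxy in place of hydrogen on a saturated ring carbon. Among the measured compounds shown here, no measured step touches this carbon; the only step available, the change from compound 1 to compound 2, altered a different position of the same fused system and was modest. On that thin basis, a step of a 1.8-fold higher number from compound 1 to compound 3 (0.26 log units; within the scatter) is expected, with wide uncertainty in direction. Compound 3 is therefore estimated at 6 nM, within the range 2 nM to 25 nM.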

Compound 3, half-maximal inhibitory concentration: 1.47 nM
Compound 3: middle estimate off by 4.1-fold (0.61 log units), on the high side; the whole stated range lies above it.
By their numbers in this assay, from the lowest: compound 3; then compound 1; then compound 2.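

In this assay, hydroxy in place of hydrogen on a saturated ring carbon gives a 2.2-fold lower number from compound 1 to compound 3 (0.35 log units; beyond the scatter) and so a stronger inhibitor, showing that this carbon, three ring bonds from the ring atom that bears a large group, tolerates the added hydroxy. Among the compounds shown here, the only earlier step, made elsewhere in the fused system, went the other way. No measurement offered here accounts for the gain. From the compounds shown here alone, whether an amine or a methoxy on this same ring carbon would give a similar number remains open, as does the effect of a carbonyl there.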